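The source may hold more compounds than are shown below. What is called first, only, known or untested is meant among the compounds shown, and "the series" means these compounds.

- compound 1 (`COc1cc(-c2nc(-c3ccccc3)[nH]c2-c2ccnc(NCCCNS(=O)(=O)c3ccccc3)n2)ccc1F`): 4520 nM
- compound 2 (`COc1cc(-c2nc(-c3ccccc3)[nH]c2-c2ccnc(NCCCNS(=O)(=O)c3ccc(F)cc3)n2)ccc1F`): 3960 nM
- compound 3 (`COc1cc(-c2nc(-c3ccccc3)[nH]c2-c2ccnc(NCCCNS(=O)(=O)c3cccc(F)c3)n2)ccc1F`): 900 nM
- compound 4 (`O=S(=O)(NCCCNc1nccc(-c2[nH]c(-c3ccccc3)nc2-c2ccc(F)c(O)c2)n1)c1ccccc1`): not yet measured

In a functional assay on LOX IMVI cells (Homo sapiens) for cytotoxicity, read by MTT assay, with a stated time of 24 h (a lower number here means a stronger inhibitor, a higher number a weaker inhibitor), compound 1 gives 4520 nM and stands level with compound 2 (a 1.1-fold lower number from compound 1 to compound 2 (0.06 log units; within the scatter)), while compound 3 lies clearly lower (a 5.0-fold lower number from compound 1 to compound 3 (0.70 log units; beyond the scatter)). Compound 4 alters a single group of compound 1 (hydrogen in place of methyl on an oxygen on an aromatic ring): hydrogen in place of methyl on an oxygen on an aromatic ring, turning methoxy to hydroxy. Going by the values given here, no measured step touches this group. All of them concern fluoro on the ring carried by the sulfonyl sulfur, so they offer only a rough sense of size, not a direction. A small change, perhaps none beyond the scatter, is therefore expected (a 1.5-fold lower number from compound 1 to compound 4 (0.18 log units; within the scatter)). Compound 4 is estimated at 3000 nM, with an expected range from 1000 nM to 9000 nM.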

Compound 4, half-maximal inhibitory concentration: 9580 nM
Estimate against measurement, compound 4: 3.2-fold (0.50 log units) below; the whole stated range lies below it.
By their numbers in this assay, from the lowest: compound 3; then compounds 2 and 1 (each within the scatter of the next); then compound 4.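

In this assay, hydroxy in place of methoxy gives a 2.1-fold higher number from compound 1 to compound 4 (0.33 log units; beyond the scatter) and so weakens the compound modestly. This is the first step shown at this group, and it shows that the methyl on the oxygen counts for something here. Unlike the fluoro steps on the ring carried by the sulfonyl sulfur, which left the number level or lowered it, this change raises it, and nothing measured here explains why. Still open, as far as these compounds go, is how an ethoxy or an amine in place of the methoxy would fare, and whether the 3-fluorophenyl of compound 3 would offset the loss seen in compound 4.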